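Acetyl for hydrogen on the aromatic amine: two parallel cases

A few compounds are considered here, and "the series" means these few. Any claim that something is new, unique, unknown or untested is made for them only; others in the source may bear on it.

Compound 1 `Nc1ccc(C2=NNC(=O)CC2)cc1` and compound 3 `Nc1cccc(C2=NNC(=O)CC2)c1` are built from the same atoms joined differently; the difference between the two cores is not broken down here. In a functional assay for inhibition, with Homo sapiens as the target (a higher number here means that more compound is needed for the effect, a lower number that less compound is needed), compound 1 gives 46.4 ug/mL. For compound 3 only a limit is known in this assay, namely > 46.4 ug/mL (the limit of > 46.4 ug/mL in this assay, at which 1 of the 3 values shown sits). Compound 2 `CC(=O)Nc1ccc(C2=NNC(=O)CC2)cc1` differs from compound 1 by acetyl in place of hydrogen on a nitrogen on an aromatic ring, and that change brought a 46-fold lower number from compound 1 to compound 2 (1.67 log units; beyond the scatter); in this assay compound 2 gives 1 ug/mL. Compound 4 `CC(=O)Nc1cccc(C2=NNC(=O)CC2)c1` differs from compound 3 by the same kind of change, (acetyl in place of hydrogen on a nitrogen on an aromatic ring), with the place described in the same words. For compound 4 a step of an at least 9.2-fold lower number from compound 3 to compound 4 (0.96 log units; beyond the scatter) is expected because a 46-fold lower number from compound 1 to compound 2 (1.67 log units; beyond the scatter) was seen for the same change, though the starting limit leaves the size uncertain. Compound 4 is therefore estimated at 5 ug/mL, expected between 1 ug/mL and 46.4 ug/mL.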

Compound 4, half-maximal effective concentration: > 46.4 ug/mL
Compound 4: only a limit was reported; the forecaster's own chance of this, stated with the estimate: 30%; middle value at least 9.2-fold (0.96 log units) away from the limit.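

No step can be read from compound 3 to compound 4 in this assay because both stand at a limit: the limit of > 46.4 ug/mL in this assay, at which 2 of the 4 values shown sit.

The compounds shown leave open whether acetyl in place of hydrogen changes anything on the core of compound 3.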